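From Nitrile to Amine on the Pendant Ring

The source may hold more compounds than are shown below. What is called first, only, known or untested is meant among the compounds shown, and "the series" means these compounds.

Compound 2 `COc1ccc(S(=O)(=O)N2CCc3cccc(-c4ccc(C#N)cc4)c32)cc1` gives the lowest number of the three measured compounds in a functional assay on NCI-H460 cells (Homo sapiens) for inhibition, with a stated time of 72 h (on this read-out higher numbers stand for weaker inhibition and lower numbers for stronger inhibition), at 29.5 nM. Compound 1 `COc1ccc(S(=O)(=O)N2CCc3cccc(-c4cccnc4)c32)cc1` gives 89.6 nM in this assay, and compound 3 `COc1ccc(S(=O)(=O)N2CCc3cccc(-c4ccncc4)c32)cc1` gives 101 nM. The measured steps are a 3.0-fold lower number from compound 1 to compound 2 (0.48 log units; beyond the scatter) and a 3.4-fold higher number from compound 2 to compound 3 (0.53 log units; beyond the scatter), while a 1.1-fold higher number from compound 1 to compound 3 (0.05 log units; within the scatter). Compound 4 `COc1ccc(S(=O)(=O)N2CCc3cccc(-c4ccc(N)cc4)c32)cc1` differs from compound 2 by amino in place of cyano on an aromatic carbon. Within the data shown here, no measured step exchanges these two groups; the measured steps show only that 4-cyanophenyl gave a modestly lower number than either pyridin-3-yl or pyridin-4-yl. An amino in place of the cyano is therefore expected to move the number modestly upward, roughly a 2.4-fold higher number from compound 2 to compound 4 (0.38 log units; beyond the scatter). Compound 4 is estimated at 70 nM, with a range from 25 nM to 200 nM.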

Compound 4, half-maximal inhibitory concentration: 288 nM
Beside the measured number, compound 4's estimate is 4.1-fold (0.61 log units) below it; measured number above the stated range.
By their numbers in this assay, from the lowest: compound 2; then compounds 1 and 3 (each within the scatter of the next); then compound 4.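

Changing one small group on the pendant ring moves the number far more than any earlier change, with a 9.8-fold higher number from compound 2 to compound 4 (0.99 log units; beyond the scatter) in this assay for amino in place of cyano. The 4-aminophenyl compound also lies beyond the scatter from both pyridine compounds, with a 2.9-fold higher number from compound 3 to compound 4 (0.46 log units; beyond the scatter) and a 3.2-fold higher number from compound 1 to compound 4 (0.51 log units; beyond the scatter), so a phenyl ring here does not by itself give the lowest number. Nothing available explains why this swap has so large an effect. On these data alone, how a carboxylic acid, a methoxy or an acetamide at this place would compare remains open.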